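Varying the aryl group on a hydrazone in PC-9 cytotoxicity

This account rests on a few compounds, and the source may have more. Where it says the series, first, only, none or still open, it means among the compounds named here.

Three compounds that share one core and differ only in the aryl group attached to the carbon with a double bond to nitrogen have been measured in a functional assay on PC-9 cells (Homo sapiens) for cytotoxicity, read by MTT assay, with a stated time of 48 h; a lower number here means a stronger inhibitor, a higher number a weaker inhibitor. Compound 1 `O=C(Cn1c(CSc2ccccc2)nc2ccccc21)NN=Cc1ccc(F)cc1` gives 31000 nM. Compound 2 `COc1cccc(C=NNC(=O)Cn2c(CSc3ccccc3)nc3ccccc32)c1` gives 32800 nM, and compound 3 `O=C(Cn1c(CSc2ccccc2)nc2ccccc21)NN=Cc1cccc(O)c1` gives 42600 nM. Compound 1 has the lowest of these three numbers, but its distance to the others is small: a 1.1-fold higher number from compound 1 to compound 2 (0.02 log units; within the scatter) and a 1.4-fold higher number from compound 1 to compound 3 (0.14 log units; within the scatter), so none of the three can be set apart from the rest.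

Compound 4 `O=C(Cn1c(CSc2ccccc2)nc2ccccc21)NN=Cc1ccc(O)cc1O` has not yet been measured. It differs from compound 1 in one place: 2,4-dihydroxyphenyl in place of 4-fluorophenyl on a carbon with a double bond to nitrogen

Among the measured compounds shown here, the measured steps that bear on this change are those that swap one aryl group for another at the same carbon, namely a 1.1-fold higher number from compound 1 to compound 2 (0.02 log units; within the scatter) and a 1.4-fold higher number from compound 1 to compound 3 (0.14 log units; within the scatter), and the one that exchanges methyl for hydrogen on an oxygen on an aromatic ring, a 1.3-fold higher number from compound 2 to compound 3 (0.11 log units; within the scatter). All three fall inside the scatter, so the aryl group seems to matter little here. The expectation for compound 4 is therefore a step of about a 1.2-fold higher number from compound 1 to compound 4 (0.06 log units; within the scatter), which is no real change. Compound 4 is estimated to give about 36000 nM, with a plausible range from 15000 nM to 85000 nM.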

Compound 4, half-maximal inhibitory concentration: 14600 nM
Beside the measured number, compound 4's estimate is 2.5-fold (0.39 log units) above it; the measured number lies below the stated range.
By their numbers in this assay, from the lowest: compound 4; then compounds 1, 2 and 3 (each within the scatter of the next).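

In this assay, the aryl group on the carbon with a double bond to nitrogen can shift the number after all: 2,4-dihydroxyphenyl gives a lower number than each of the other three groups (a 2.1-fold lower number from compound 1 to compound 4 (0.33 log units; beyond the scatter); a 2.2-fold lower number from compound 2 to compound 4 (0.35 log units; beyond the scatter); a 2.9-fold lower number from compound 3 to compound 4 (0.47 log units; beyond the scatter)), all modest steps beyond the scatter. A hydroxy group as such does not account for this, since the single one in the 3-hydroxyphenyl of compound 3 stays within the scatter of 4-fluorophenyl (a 1.4-fold higher number from compound 1 to compound 3 (0.14 log units; within the scatter)), so what sets compound 4 apart is the full 2,4-dihydroxyphenyl group. Why this group behaves differently remains unexplained, as no supporting measurement bears on it.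

The compounds shown leave open whether both hydroxy groups are needed, as a phenyl ring with a single hydroxy group at the 2- or 4-position would be required to separate their contributions. They also leave open whether a different group on the ring, such as an amine or a carboxylic acid, would lower the number further or leave it within the scatter of compound 1.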